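The source may report more compounds than this note shows. Statements on the series, on what has been measured and on what is new or still open speak of the compounds shown alone.

Of the compounds shown here, two sharing one core have been measured in an ADME assay on L02 cells (Homo sapiens) for cytotoxicity, read by MTT assay, with a stated time of 48 h; a lower number here means a stronger inhibitor, a higher number a weaker inhibitor. Compound 1 `CCn1c(C(=O)NCCN(C)C)ccc1C(CC)(CC)c1ccc(OCC(O)C(C)(C)C)c(C)c1` gives 2600 nM, and compound 2 `C#CCNC(=O)c1ccc(C(CC)(CC)c2ccc(OCC(O)C(C)(C)C)c(C)c2)n1CC` gives 4400 nM. These two values lie within the scatter of each other, so compound 2 cannot be ranked against compound 1 on these numbers. Compound 3 `CCn1c(C(=O)N(C)CCC#N)ccc1C(CC)(CC)c1ccc(OCC(O)C(C)(C)C)c(C)c1` keeps the shared core and differs from compound 2 only in the group on a carbonyl carbon: (2-cyanoethyl)(methyl)amino in place of propargylamino on a carbonyl carbon. Here (2-cyanoethyl)(methyl)amino stands in place of propargylamino; neither group carries a net charge, and each holds a triple bond outside aromatic rings. For the measured compounds named here, the only measured step that bears on this change is a 1.7-fold higher number from compound 1 to compound 2 (0.23 log units; within the scatter), which also falls in the side chain on that carbonyl carbon. It is a single small step, so it gives no ground to expect a move beyond the scatter in this assay, and the expectation stays anchored on compound 2 at 4400 nM. The expected step is a 1.1-fold lower number from compound 2 to compound 3 (0.04 log units; within the scatter). For compound 3 the estimated value is 4000 nM, with an expected range from 1600 nM to 10000 nM.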

Compound 3, half-maximal inhibitory concentration: 14900 nM
For compound 3 the middle estimate is 3.7-fold (0.57 log units) below the measured one; the whole stated range lies below it.
By their numbers in this assay, from the lowest: compounds 1 and 2 (each within the scatter of the next); then compound 3.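

In this assay, for the compounds shown here, the side chain on a carbonyl carbon whose other neighbour is an aromatic carbon proves able to move the number beyond the scatter: (2-cyanoethyl)(methyl)amino in place of propargylamino gives a 3.4-fold higher number from compound 2 to compound 3 (0.53 log units; beyond the scatter), whereas the only earlier step here stayed within it. The same group in place of (2-(dimethylamino)ethyl)amino gives a 5.7-fold higher number from compound 1 to compound 3 (0.76 log units; beyond the scatter) as a modest step, so compound 3 stands apart from both compound 1 and compound 2, the only one of the three without the amide hydrogen. No measurement shown here accounts for this shift, and the change alters several features at once, so the result gives a direction at this place but no reason for it.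

The compounds shown leave open whether the higher number goes with the methyl on the amide nitrogen or with the nitrile-bearing chain. Compounds carrying (2-cyanoethyl)amino, which keeps the amide hydrogen, or methyl(propargyl)amino, which removes it while keeping the propargyl chain, would separate these two parts of the change.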